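The source may hold more compounds than are shown below. What is called first, only, known or untested is meant among the compounds shown, and "the series" means these compounds.

Of the compounds shown here, three have been measured in a functional assay on MCF-10A cells (Homo sapiens) for antiproliferative activity, with a stated time of 48 h; on this read-out lower numbers stand for an effect already at smaller amounts and higher numbers for an effect only at larger amounts of compound. Compound 1, `COc1ccc(CNc2cc(C)nc3ccc(OC)cc23)cc1`, gives 9700 nM. Compound 2, `COc1cccc(CNc2cc(C)nc3ccc(OC)cc23)c1`, gives 12500 nM. Compound 3, `COc1ccc2nc(C)cc(NCc3ccc(OC)c(F)c3)c2c1`, gives 10300 nM.

Compound 3 differs from compound 1 in one place only: fluoro in place of hydrogen on an aromatic carbon. This change gave a 1.1-fold higher number from compound 1 to compound 3 (0.03 log units; within the scatter). Compound 2 and compound 1 are built from the same atoms joined differently; the difference between the two cores is not broken down here, and their two values lie within the scatter of each other.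

Compound 4, `COc1ccc2nc(C)cc(NCc3ccc(F)c(OC)c3)c2c1`, has not yet been measured in this assay. It differs from compound 2 by fluoro in place of hydrogen on an aromatic carbon. Within the data shown here, this is the same kind of change as the one made from compound 1 to compound 3, but not the same: in compound 3 the fluoro sits meta to a large group, whereas in compound 4 it sits para to a large group. The expected step is a 1.0-fold higher number from compound 2 to compound 4 (0.02 log units; within the scatter), about as small as the earlier one, because a 1.1-fold higher number from compound 1 to compound 3 (0.03 log units; within the scatter) stayed within the scatter. Among the measured compounds shown here, only one earlier step supports this, so the range is kept wide. Compound 4 is therefore expected to give 13000 nM, with a likely range from 7000 nM to 25000 nM.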

Compound 4, half-maximal effective concentration: 12900 nM
For compound 4 the middle estimate is 1.0-fold (0.00 log units) above the measured one; measured number inside the range.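

In this assay, among these compounds, putting fluoro in place of hydrogen on an aromatic carbon gives a 1.0-fold higher number from compound 2 to compound 4 (0.01 log units; within the scatter), so on this second core too the swap leaves no step that can be told apart from ordinary repeat variation. Set side by side, the two cases agree with each other: the same change on two cores in this assay, a 1.1-fold higher number (0.03 log units; within the scatter) from compound 1 to compound 3 and a 1.0-fold higher number (0.01 log units; within the scatter) from compound 2 to compound 4, 1.0-fold (0.01 log units) apart, within the scatter of two such steps. This shows that, in these two pairs, the fluoro swap carries from one core to the other with the same outcome, a step too small to read, but it does not show that fluoro is without effect elsewhere in the series, and two pairs are too few to support a general rule.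

The compounds shown leave open what a different group on the same aromatic carbon would do, for example an amine or a carboxylic acid in place of the fluoro. They also leave open whether a longer chain in place of the methoxy group would give a step beyond the scatter.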